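This account rests on a few compounds, and the source may have more. Where it says the series, first, only, none or still open, it means among the compounds named here.

Of the compounds shown here, three sharing one core have so far been tested in a functional assay (muscle tissue) with Cavia porcellus as the target; on this read-out higher numbers stand for an effect only at larger amounts of compound and lower numbers for an effect already at smaller amounts. Compound 1 `COC(=O)C1=C(C)NC(C)=C(C(=O)OC)C1c1ccccc1` gives 28.2 nM, compound 2 `COC(=O)C1=C(C)N=C(C)/C(=C(\O)OC)C1c1ccccc1I` gives 46.8 nM, and compound 3 `COC(=O)C1=C(C)N=C(C)/C(=C(\O)OC)C1c1cccc(OC(C)=O)c1` gives 6030 nM. Among these three numbers compound 2 holds the second highest. Its nearest neighbour is compound 1, whose number differs from it by less than the usual scatter, so the two cannot be told apart, while compound 3 lies far away, well beyond the scatter.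

Compound 4 `COC(=O)C1=C(C)N=C(C)/C(=C(\O)OC)C1c1cc(C)ccc1C` has not yet been measured. For the measured compounds named here, it differs from compound 2 in a single place: 2,5-dimethylphenyl in place of 2-iodophenyl on a saturated ring carbon No two measured compounds differ in only one place, so nothing measured so far shows the effect of exactly this exchange. Going by the values given here, the measured numbers show only that compound 1 and compound 2 sit close together while compound 3 sits far higher.

For compound 4 a step of a 1.7-fold higher number from compound 2 to compound 4 (0.23 log units; within the scatter) is expected, a modest rise in number that may still fall inside the scatter. The value of compound 4 in this assay is therefore estimated at 80 nM, with a range from 20 nM to 400 nM.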

Compound 4, half-maximal effective concentration: 100 nM
Compound 4: the middle estimate sits 1.3-fold (0.10 log units) below what was measured; the measured number falls inside the stated range.
By their numbers in this assay, from the lowest: compounds 1 and 2 (each within the scatter of the next); then compound 4; then compound 3.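

In this assay, for the compounds shown here, putting 2,5-dimethylphenyl in place of 2-iodophenyl on the saturated ring carbon gives a 2.1-fold higher number from compound 2 to compound 4 (0.33 log units; beyond the scatter) and is the first exchange at this position that can be read on its own. The step is modest, but it shows that the number responds to swapping one substituted phenyl group for another, even though both groups have no hydrogen-bond donors or acceptors and no net charge. Nothing available explains why the number moves.

Whether the step comes from losing the iodine or from gaining the two methyl groups stays open, since both changes arrive together and the compounds shown do not separate them. Also open, on these data alone, is how this position would respond to a phenyl ring carrying an amine or a carboxylic acid.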